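Swapping chloro for fluoro on the aryl ring of compound 2

A few compounds are considered here, and "the series" means these few. Any claim that something is new, unique, unknown or untested is made for them only; others in the source may bear on it.

Compound 1 `CCCc1n[nH]c2c(=O)n(NC(=O)c3ccccc3)c(-c3cccc([N+](=O)[O-])c3)nc12` gives 18.7% in a functional assay on HT-29 cells (Homo sapiens) for cytotoxicity, read by sulforhodamine B assay, with a stated time of 2 days, tested at 100 uM; on this read-out lower numbers stand for less inhibition and higher numbers for more inhibition at the one concentration tested (going by the name of the read-out). Compound 2 `O=C(Nn1c(-c2cccc([N+](=O)[O-])c2)nc2c(-c3ccc(Cl)cc3)n[nH]c2c1=O)c1ccccc1` gives 87.8%, the highest of the two numbers, and the step of a number 69.1 percentage points higher from compound 1 to compound 2 (beyond the scatter) is large. Compound 3 `O=C(Nn1c(-c2cccc([N+](=O)[O-])c2)nc2c(-c3ccc(F)cc3)n[nH]c2c1=O)c1ccccc1` differs from compound 2 by fluoro in place of chloro on an aromatic carbon. Going by the values given here, no measured step swaps one halogen for another; the only one shows that a 4-chlorophenyl group here carries most of the inhibition. Keeping a similar aryl group, compound 3 is expected to lose little, with a step of a number 11.8 percentage points lower from compound 2 to compound 3 (beyond the scatter), so compound 3 is estimated at 76%, between 52% and 92%.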

Compound 3, a percentage reported as inhibition, at one concentration (the size of the read-out at that concentration, not a potency): 92%
Beside the measured number, compound 3's estimate is 16 percentage points below it; the measured number falls inside the stated range.
By their numbers in this assay, from the lowest: compound 1; then compounds 2 and 3 (each within the scatter of the next).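

In this assay, fluoro in place of chloro gives a number 4.2 percentage points higher from compound 2 to compound 3 (within the scatter), so the two halogens cannot be told apart at this place on the ring. Replacing propyl with 4-fluorophenyl gives a number 73.3 percentage points higher from compound 1 to compound 3 (beyond the scatter), showing that the large gain seen with 4-chlorophenyl does not depend on chlorine alone. No available measurement explains this result. As far as these compounds go, it remains open how a plain phenyl would compare, and so whether any halogen is needed at all. A phenyl ring carrying an amine or a carboxylic acid at this place is also untested among the compounds shown.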